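A few compounds are considered here, and "the series" means these few. Any claim that something is new, unique, unknown or untested is made for them only; others in the source may bear on it.

Series notes, solubility. Of the compounds shown here, two on a shared core have been measured in a physicochemical assay for solubility, read by HPLC, with a stated time of 24 h; on this read-out lower numbers stand for lower solubility and higher numbers for higher solubility. Compound 1 `CN(CCC#N)C[C@H]1CN(c2ccc(-n3cc(-c4ccccn4)cn3)c(F)c2)C(=O)O1` gives 64500 nM in this assay. Compound 2 `COC[C@H]1CN(c2ccc(-n3cc(-c4ccccn4)cn3)c(F)c2)C(=O)O1` gives 36200 nM in this assay and so holds the lowest of the two numbers; its nearest neighbour is compound 1, and the step of a 1.8-fold lower number from compound 1 to compound 2 (0.25 log units; within the scatter) does not exceed the scatter.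

Compound 3 `O=C1O[C@@H](CSc2cccs2)CN1c1ccc(-n2cc(-c3ccccn3)cn2)c(F)c1` is not yet measured. The change from compound 2 is (thiophen-2-yl)sulfanyl in place of methoxy on a saturated chain carbon bound to a saturated ring carbon. Among the measured compounds shown here, the only measured step, a 1.8-fold lower number from compound 1 to compound 2 (0.25 log units; within the scatter), sits at the same place on the chain but exchanges other groups, and it stayed within the scatter, so it gives little direct guidance on this exchange. A step beyond the scatter in this assay is nevertheless expected for compound 3, downward, of about a 7.2-fold lower number from compound 2 to compound 3 (0.86 log units; beyond the scatter). Compound 3 is therefore estimated at 5000 nM in this assay, with a range from 800 nM to 30000 nM.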

Compound 3, solubility: 8500 nM
Compound 3: the middle estimate sits 1.7-fold (0.23 log units) below what was measured; the range from low to high includes it.
By their numbers in this assay, from the lowest: compound 3; then compounds 2 and 1 (each within the scatter of the next).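

In this assay the place on a saturated chain carbon bound to a saturated ring carbon now shows a step beyond the scatter: (thiophen-2-yl)sulfanyl in place of methoxy gives a 4.3-fold lower number from compound 2 to compound 3 (0.63 log units; beyond the scatter) and remains a modest change. The same group in place of (2-cyanoethyl)(methyl)amino gives a 7.6-fold lower number from compound 1 to compound 3 (0.88 log units; beyond the scatter) in the same direction, so the exchange of the entering group reads the same against both earlier groups, although the earlier exchange between those two stayed within the scatter. No supporting measurement bears on the origin of these steps.

On these data alone, the entering group brings the sulfur link and the thiophene ring together, so their separate shares remain open. Methylsulfanyl or (thiophen-2-yl)oxy at this place would separate them, and a carboxylic acid or a longer chain remains untested in these compounds.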